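Aryl-thiophene nitroimidazooxazine series: cytotoxicity notes

A few compounds are considered here, and "the series" means these few. Any claim that something is new, unique, unknown or untested is made for them only; others in the source may bear on it.

Measured in an ADME assay on Vero cells (Chlorocebus sabaeus) for cytotoxicity, with a stated time of 72 h; on this read-out higher numbers stand for weaker inhibition and lower numbers for stronger inhibition:
compound 1 `O=[N+]([O-])c1cn2c(n1)OC[C@@H](OCc1ccc(-c3ccc(C(F)(F)F)cc3)s1)C2`, > 128000 nM, a limit of the assay
compound 2 `O=[N+]([O-])c1cn2c(n1)OC[C@@H](OCc1ccc(-c3ccc(F)cc3)s1)C2`, > 128000 nM, a limit of the assay
compound 3 `O=[N+]([O-])c1cn2c(n1)OC[C@@H](OCc1ccc(-c3ccc(OC(F)F)cc3)s1)C2`, > 128000 nM, a limit of the assay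

For the measured compounds named here, compound 2 stands at the limit of > 128000 nM in this assay, at which 3 of the 3 values shown sit, where every value so far also sits, so no separation among the three is readable. Compound 4 `COc1ccc(-c2ccc(CO[C@@H]3COc4nc([N+](=O)[O-])cn4C3)s2)cn1` differs from compound 2 by 6-methoxypyridin-3-yl in place of 4-fluorophenyl on an aromatic carbon. The measured steps nearest to this change are a step that the two limits leave unreadable from compound 1 to compound 2 and a step that the two limits leave unreadable from compound 2 to compound 3; both are unreadable. Going by the values given here, no measured step therefore points to a readable change in this assay, and compound 4 is expected to stay at the limit as well. The estimate for compound 4 is 150000 nM, range 60000 nM to 400000 nM, which means an expected step that the limit leaves unreadable from compound 2 to compound 4.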

Compound 4, half-maximal inhibitory concentration: > 128000 nM
Compound 4: a limit, no number (the forecaster's own chance of this, stated with the estimate: 85%); the middle value lies beyond the limit too.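

No step can be read from compound 2 to compound 4, as both sit at a limit of the assay: the limit of > 128000 nM in this assay, at which 4 of the 4 values shown sit.

The compounds shown leave open any actual inhibitory concentration, and any ranking among the four compounds, in this assay.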